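Methylsulfonyl in Place of Methylsulfanyl

This account rests on a few compounds, and the source may have more. Where it says the series, first, only, none or still open, it means among the compounds named here.

In a functional assay on BXPC-3 cells (Homo sapiens) for antiproliferative activity, read by MTT assay, with a stated time of 24 h (a lower number here means a stronger inhibitor, a higher number a weaker inhibitor), compound 3 `CCN(CC)CCNC(=O)c1cc(C(CC)(CC)c2ccc(OCSC)c(C)c2)cn1CC` gives 4110 nM, and compound 2 `CCN(CC)CCNC(=O)c1ccc(C(CC)(CC)c2ccc(OCSC)c(C)c2)n1CC` gives 5130 nM, so these two lie within the scatter of each other. Compound 1 `CCn1c(C(=O)N[C@H](C)CO)ccc1C(CC)(CC)c1ccc(OCS(=O)(=O)c2ccccc2)c(C)c1` gives 10000 nM, and its gap to compound 3 lies beyond the scatter. Compound 4 `CCN(CC)CCNC(=O)c1cc(C(CC)(CC)c2ccc(OCS(C)(=O)=O)c(C)c2)cn1CC` departs from compound 3 by one change: methylsulfonyl in place of methylsulfanyl on a saturated chain carbon bound to an oxygen on an aromatic ring, with methylsulfonyl in place of methylsulfanyl on a saturated chain carbon bound to an oxygen on an aromatic ring. Among the measured compounds shown here, no measured pair isolates this change. Compound 1 also carries a sulfonyl group, but it differs in other places too, so it offers only a weak hint of a higher number. The expected step of a 1.3-fold higher number from compound 3 to compound 4 (0.13 log units; within the scatter) is small, probably not beyond the scatter, and if anything upward. For compound 4 the estimated value is 5500 nM, with an expected range of 2500 nM to 12000 nM.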

Compound 4, half-maximal inhibitory concentration: 30400 nM
The estimate for compound 4 lay 5.5-fold (0.74 log units) below the measured number, outside the stated range (above it).
By their numbers in this assay, from the lowest: compounds 3, 2 and 1 (each within the scatter of the next, the first and the last beyond it); then compound 4.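

In this assay, the change of methylsulfanyl to methylsulfonyl on a saturated chain carbon bound to an oxygen on an aromatic ring gives a 7.4-fold higher number from compound 3 to compound 4 (0.87 log units; beyond the scatter) and so is not silent at this position. This single matched pair shows that the position responds to the change, and that the number moves upward. Nothing measured here accounts for the step.

Going by these compounds, it remains open whether a methylsulfinyl group or an ethylsulfanyl group would stay near compound 3 or move towards compound 4. On these data alone, whether the same change carries over to the core of compound 2 is also open.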